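The compounds below may be only part of what the source reports. "The series", "measured", "known", "first", "only" and "open" are said of these compounds alone.

Measured so far in a physicochemical assay for lipophilicity, using the shake flask method, at pH 7.4; on this read-out lower numbers stand for lower lipophilicity and higher numbers for higher lipophilicity:
- compound 1 `CCCC(Oc1ccc(-n2cc(OC)cn2)cc1)c1ccc(C(=O)NCCC(=O)O)cc1` at 1.4
- compound 2 `CCC(Oc1ccc(-n2cc(C(F)(F)F)cn2)cc1)c1ccc(C(=O)NCCC(=O)O)cc1` at 1.9
- compound 3 `CCCC(Nc1ccc(-n2cnc(C(F)(F)F)c2)cc1)c1ccc(C(=O)NCCC(=O)O)cc1` at 1.3

Compound 1 with 1.4 lies within the usual scatter of compound 3 with 1.3 in this assay and so cannot be separated from it. Compound 2 with 1.9 stands higher than compound 1, and that gap lies beyond the scatter.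

The next compound to be measured is compound 4 `CCCC(Oc1ccc(-n2cc(C)cn2)cc1)c1ccc(C(=O)NCCC(=O)O)cc1` and its core is that of compound 1. Methyl takes the place of methoxy on an aromatic carbon of a five-membered aromatic ring with 2 nitrogen, and the counted difference reads methyl in place of methoxy on an aromatic carbon for this swap.

For the measured compounds named here, the three measured compounds differ from each other in more than one place, so no measured pair isolates this change. The expectation therefore rests on the structural change alone and remains uncertain. A modest upward step in this assay is expected, estimated as a number 0.30 log units higher from compound 1 to compound 4 (within the scatter) and so about the size of the usual scatter. Compound 4 is estimated at 1.7 with an expected range from 1.35 to 2.05 on this read-out.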

Compound 4, distribution coefficient: 2.1
Estimate against measurement, compound 4: 0.40 log units below; the measured number lies above the stated range.
By their numbers in this assay, from the lowest: compounds 3 and 1 (each within the scatter of the next); then compounds 2 and 4 (each within the scatter of the next).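

In this assay, the exchange of 4-methoxy-1H-pyrazol-1-yl for 4-methyl-1H-pyrazol-1-yl gives a number 0.70 log units higher from compound 1 to compound 4 (beyond the scatter), and this is the only pair shown that differs in one place. The substituent on this aromatic carbon of the five-membered aromatic ring with 2 nitrogen therefore registers on this read-out: with the rest of the core of compound 1 held constant, methyl in place of methoxy moves the number beyond the scatter, something that compounds 1, 2 and 3 could not show, as they differ from each other in more than one place. No measurement at hand bears on the origin of this step.

Steps among compounds 1, 2 and 3 cannot be read, so the effect of trifluoromethyl at this position on the core of compound 1 stays undefined. Also open, on these data alone, are how a nitrile, a hydroxyl, an amine or an ethyl group at the same aromatic carbon would compare with methyl and methoxy, and whether the same swap gives a similar step on a core with a different chain or linker.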